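Swapping the sulfonylpiperidine for a methylpyridine

This account rests on a few compounds, and the source may have more. Where it says the series, first, only, none or still open, it means among the compounds named here.

Measured compounds:
compound 1: `CC(C)(C)OC(=O)N1CCN(c2ncc(OCc3ccc(S(C)(=O)=O)cc3)nn2)CC1` — 103%
compound 2: `C[C@@H]1CN(C(=O)OC(C)(C)C)CCN1c1ncc(OCC2CCN(S(C)(=O)=O)CC2)cn1` — 67%

In a functional assay on isolated protein with Glucose-dependent insulinotropic receptor (Mus musculus) as the target, read by HTRF and cAMP accumulation, with a stated time of 45 min (a lower number here means a smaller maximal response, a higher number a larger maximal response), compound 1 gives 103%, while compound 2 gives 67%. Compound 2 thus stands lowest of the two values, and its gap to compound 1 lies beyond the scatter. For the measured compounds named here, no step between compounds that differ in a single place is available, so the two values show only that compound 2 reaches a smaller maximal response than compound 1.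

Compound 3, `Cc1cnccc1COc1cnc(N2CCN(C(=O)OC(C)(C)C)C[C@H]2C)nc1`, awaits measurement in this assay. It differs from compound 2 in one place: 3-methylpyridin-4-yl in place of 1-(methylsulfonyl)piperidin-4-yl on a saturated chain carbon bound to an oxygen on an aromatic ring. A six-membered aromatic ring with one hetero atom now sits where a six-membered non-aromatic ring stood. Compound 1 gives 103%, and compound 3 is expected to land nearer to that value than compound 2 does. The step of a number 18 percentage points higher from compound 2 to compound 3 (beyond the scatter) is therefore estimated to be upward and beyond the scatter. For compound 3 the expected value is 85%, within a range from 60% to 105%.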

Compound 3, intrinsic activity: the largest response reached, in percent of the reference agonist's in the Glucose-dependent insulinotropic receptor assay: 60%
For compound 3 the middle estimate is 25 percentage points above the measured one, within the range that was stated.
By their numbers in the Glucose-dependent insulinotropic receptor assay, from the lowest: compounds 3 and 2 (each within the scatter of the next); then compound 1.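

In the Glucose-dependent insulinotropic receptor assay the exchange of 1-(methylsulfonyl)piperidin-4-yl for 3-methylpyridin-4-yl on a saturated chain carbon bound to an oxygen on an aromatic ring gives a number 7 percentage points lower from compound 2 to compound 3 (within the scatter) and so, at this position, a six-membered aromatic ring with one hetero atom and a six-membered non-aromatic ring cannot be told apart by maximal response. The two compounds also cannot be told apart on lipophilicity: in a physicochemical assay for lipophilicity, using the shake flask method, in phosphate buffer, measured as octanol-water partition, at pH 7.4 (on this read-out lower numbers stand for lower lipophilicity and higher numbers for higher lipophilicity), compound 2 gives 3.5 and compound 3 gives 3.8 on the distribution coefficient, so the exchange of the sulfonyl-bearing group for the pyridine moves neither read-out beyond the scatter. No measured information is at hand that would account for this outcome.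

On these data alone, what the methyl group of 3-methylpyridin-4-yl adds at this position stays open, as does the response that an unsubstituted phenyl ring or a 1-acetylpiperidin-4-yl group would give in its place. As far as these compounds go, it also stays open whether any group at this position, an amine or a carboxylic acid among them, can give a larger maximal response on the core shared by compound 2 and compound 3.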